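Moving the methoxy group: compound 3 to compound 4

A few compounds are considered here, and "the series" means these few. Any claim that something is new, unique, unknown or untested is made for them only; others in the source may bear on it.

Measured so far:
- compound 1 `CNc1nc(Nc2ccc(C)c(N)c2)ncc1C(=O)Nc1cc(NC(=O)c2cccc(C(F)(F)F)c2)ccc1C` — 14 nM
- compound 2 `CNc1nc(Nc2ccc(C)c([N+](=O)[O-])c2)ncc1C(=O)Nc1cc(NC(=O)c2cccc(OC)c2)ccc1C` — 480 nM
- compound 3 `CNc1nc(Nc2ccc(C)c(N)c2)ncc1C(=O)Nc1cc(NC(=O)c2ccccc2OC)ccc1C` — 1980 nM

These three compounds share one core and were tested in a functional assay on K562 cells (Homo sapiens) for antiproliferative activity, read by CellTiter-Glo and CCK-8 assay, with a stated time of 72 h; a higher number here means a weaker inhibitor of growth, a lower number a stronger inhibitor of growth. Compound 3 gives the highest number of the three in this assay; compound 2 sits closer to it, and compound 1 lies far below it. Among the compounds with values here, the one step recorded within this set is a 140-fold higher number from compound 1 to compound 3 (2.15 log units; beyond the scatter), which changes two things at once: the group on the carbonyl carbon and where its substituent sits.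

Compound 4 `CNc1nc(Nc2ccc(C)c(N)c2)ncc1C(=O)Nc1cc(NC(=O)c2cccc(OC)c2)ccc1C` is not yet measured. It differs from compound 3 by 3-methoxyphenyl in place of 2-methoxyphenyl on a carbonyl carbon. Within the data shown here, no recorded step isolates this change, so the expectation rests on neighbours. Compound 2 carries the same 3-methoxyphenyl as compound 4. In this assay compound 2 gives 480 nM. Compound 1 shares the amino group of compound 4. In this assay compound 1 gives 14 nM. Both values lie well below that of compound 3, so compound 4 is expected to show a clearly lower number, a step of a 9.9-fold lower number from compound 3 to compound 4 (1.00 log units; beyond the scatter). Compound 4 is estimated at 200 nM, with a range from 50 nM to 900 nM.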

Compound 4, concentration for 50% growth inhibition: 330 nM
Beside the measured number, compound 4's estimate is 1.7-fold (0.22 log units) below it; the measured number falls inside the stated range.
By their numbers in this assay, from the lowest: compound 1; then compounds 4 and 2 (each within the scatter of the next); then compound 3.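

In this assay, moving the methoxy group alone gives a 6.0-fold lower number from compound 3 to compound 4 (0.78 log units; beyond the scatter) and so shows that 3-methoxyphenyl and 2-methoxyphenyl are not interchangeable on this carbonyl carbon, which the earlier step could not separate because it also changed the group. Methoxy in place of trifluoromethyl on an aromatic carbon gives a 24-fold higher number from compound 1 to compound 4 (1.37 log units; beyond the scatter) and shows that the identity of the group matters too, even when both compounds carry it at the same ring position. Amino in place of nitro on an aromatic carbon gives a 1.5-fold lower number from compound 2 to compound 4 (0.16 log units; within the scatter) and so has no effect here that can be told apart from the scatter.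

From the compounds shown here alone, how an ethoxy group or a carboxylic acid would compare in place of the methoxy remains open. Nothing available explains why these steps have the sizes they do.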